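Amide Swap on a Shared Core: Expecting Compound 3

The compounds below may be only part of what the source reports. "The series", "measured", "known", "first", "only" and "open" are said of these compounds alone.

Compound 1: `Cc1nc(C(=O)Nc2ccc(Cl)c(-c3nnc4c(Cl)cccn34)c2)cs1` gives > 100000 nM
Compound 2: `CS(=O)(=O)c1cccc(C(=O)Nc2ccc(Cl)c(-c3nnc4c(Cl)cccn34)c2)c1` gives > 100000 nM

In a functional assay on MDA-MB-468 cells (Homo sapiens) for antiproliferative activity, read by MTT assay, with a stated time of 72 h (on this read-out lower numbers stand for stronger inhibition and higher numbers for weaker inhibition), compound 1 gives > 100000 nM, a limit of the assay rather than a number. Compound 2 gives > 100000 nM, likewise a limit. Compound 2 therefore stands at the edge of what the assay can report, as the limit of > 100000 nM in this assay, at which 2 of the 2 values shown sit, shows. Among the measured compounds shown here, the single measured step, a step that the two limits leave unreadable from compound 1 to compound 2, cannot be read, so no measured step bears on the change to compound 3 `O=C(Nc1ccc(Cl)c(-c2nnc3c(Cl)cccn23)c1)c1ccccc1Cl`: 2-chlorophenyl in place of 3-(methylsulfonyl)phenyl on a carbonyl carbon. With nothing readable to lean on, no step beyond the scatter is expected for a number no higher from compound 2 to compound 3 (the limit leaves the size open), and compound 3 is expected most likely to reach only the limit too. The estimate for compound 3 is 100000 nM, ranging from 30000 nM to 300000 nM.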

Compound 3, half-maximal inhibitory concentration: > 100000 nM
Compound 3: a limit, no number (the forecaster's own chance of this, stated with the estimate: 85%); the middle value sits exactly at the limit.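

Compound 3 also gives only a limit, not a number, so neither step to it, from compound 1 or from compound 2, can be read: the limit of > 100000 nM in this assay, at which 3 of the 3 values shown sit.

The compounds shown leave open which group on the carbonyl carbon, if any, would give a measurable value in this assay.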